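Cyano in Place of Hydroxy: Expected Toxicity of Compound 4

The source may hold more compounds than are shown below. What is called first, only, known or untested is meant among the compounds shown, and "the series" means these compounds.

Compound 1, `Cn1c(-c2ccccc2)cnc1NC(=O)c1ccc(F)cc1`, in a toxicity assay on THP-1 cells (Homo sapiens) for inhibition (on this read-out higher numbers stand for lower toxicity in this test and lower numbers for higher toxicity in this test), gives > 100000 nM, a limit of the assay. Compound 2, `COc1ccc(-c2cnc(NC(=O)c3ccccc3O)n2C)cc1`, gives > 100000 nM, likewise a limit. Compound 3, `Cc1ccc(C(=O)Nc2ncc(-c3ccccc3)n2C)cc1`, gives > 50000 nM, also a limit.

Compound 2 thus stands at the limit described by the limit of > 100000 nM in this assay, at which 2 of the 3 values shown sit, while compound 3 sits at the limit of > 50000 nM in this assay, at which 1 of the 3 values shown sits. Among the measured compounds shown here, the one single-point step measured, a step that the two limits leave unreadable from compound 1 to compound 3, is unreadable. Compound 4, `COc1ccc(-c2cnc(NC(=O)c3ccccc3C#N)n2C)cc1`, differs from compound 2 by cyano in place of hydroxy on an aromatic carbon. For the measured compounds named here, no measured step involves a cyano or a hydroxy group, so nothing in this set bears on the change. The estimate for compound 4 therefore follows compound 2, with an expected step of a number no higher from compound 2 to compound 4 (the limit leaves the size open), nothing beyond the scatter. Compound 4 is expected at 100000 nM, between 30000 nM and 300000 nM.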

Compound 4, half-maximal cytotoxic concentration: > 100000 nM
Compound 4 ended at the assay's limit (the forecaster's own chance of this, stated with the estimate: 70%); the middle value lies on the limit itself.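

Compound 2 and compound 4 both end at a limit of the assay, and the step between them cannot be read. The compounds shown leave open whether cyano in place of hydroxy changes the result in this assay at all.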